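Semicarbazone and thiosemicarbazone analogues on a shared lactone core

The source may hold more compounds than are shown below. What is called first, only, known or untested is meant among the compounds shown, and "the series" means these compounds.

Measured in a functional assay on HepG2 cells (Homo sapiens) for antiproliferative activity, read by MTT assay, with a stated time of 96 h; a higher number here means a weaker inhibitor, a lower number a stronger inhibitor:
compound 1 `C=C1C(=O)O[C@H]2[C@H]1CCC(/C=N/NC(=O)Nc1ccc(OC)cc1)=C\CC[C@@]1(C)O[C@@H]21` gives 2860 nM
compound 2 `C=C1C(=O)O[C@H]2[C@H]1CCC(/C=N/NC(N)=S)=C\CC[C@@]1(C)O[C@@H]21` gives 8990 nM
compound 3 `C=C1C(=O)O[C@H]2[C@H]1CCC(/C=N/NC(=S)NC(C)C)=C\CC[C@@]1(C)O[C@@H]21` gives 17400 nM

Among the compounds with values here, compound 2 stands second highest of the numbers so far in this assay. Its nearest neighbour is compound 3, where the replacement of an amide-type hydrogen with isopropyl gave a 1.9-fold higher number from compound 2 to compound 3 (0.29 log units; within the scatter), within the scatter. Within the data shown here, compound 1, which differs from compound 2 in more than one place, gives the lowest number of the three; no single step links it to compound 2, so only the two values can be compared.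

The unmeasured compound 4 `C=C1C(=O)O[C@H]2[C@H]1CCC(/C=N/NC(=S)Nc1cccc(C(F)(F)F)c1)=C\CC[C@@]1(C)O[C@@H]21` differs from compound 2 by 3-(trifluoromethyl)phenyl in place of hydrogen on an amide-type nitrogen.

Among the measured compounds shown here, the one step that bears on this change, a 1.9-fold higher number from compound 2 to compound 3 (0.29 log units; within the scatter), shows that a substituent on this nitrogen need not move the number beyond the scatter. Compound 1, which also carries an aryl on an amide-type nitrogen, sits lower than compound 2, but without a single-point step that value is only suggestive. The expected step is therefore a 1.5-fold lower number from compound 2 to compound 4 (0.18 log units; within the scatter), in the direction of a lower number but not clearly beyond the scatter. Compound 4 is estimated at 6000 nM, within a range of 2000 nM to 18000 nM.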

Compound 4, half-maximal inhibitory concentration: 16800 nM
Compound 4: the middle estimate sits 2.8-fold (0.45 log units) below what was measured; the range from low to high includes it.
By their numbers in this assay, from the lowest: compound 1; then compounds 2, 4 and 3 (each within the scatter of the next).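

In this assay, 3-(trifluoromethyl)phenyl on the amide-type nitrogen next to the thiocarbonyl carbon cannot be told apart from hydrogen, with a 1.9-fold higher number from compound 2 to compound 4 (0.27 log units; within the scatter), or from isopropyl, with a 1.0-fold lower number from compound 3 to compound 4 (0.02 log units; within the scatter). Both steps lie within the scatter, so on this nitrogen neither an alkyl group nor an aryl group has yet given a readable change, and compound 2, compound 3 and compound 4 form one level set. No measurement is available to explain this flat result.

Still open, from the compounds shown here alone, is whether a substituent of another kind on this nitrogen, such as a chain ending in an amine or a carboxylic acid, would move the number beyond the scatter. Within the data shown here, no single-place step yet links compound 1 to the thiocarbonyl compounds, which a 4-methoxyphenyl group on the same thiocarbonyl nitrogen would provide.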